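Shortening the nitrile chain of compound 2

A few compounds are considered here, and "the series" means these few. Any claim that something is new, unique, unknown or untested is made for them only; others in the source may bear on it.

Measured so far in a physicochemical assay for lipophilicity, at pH 7.4; a lower number here means a more polar compound, a higher number a more lipophilic compound:
- compound 1 `Cc1cc(CCC#N)cc(C)c1Oc1cc(Nc2ccc(C#N)cc2)c(N)cc1CO` gives 3.68
- compound 2 `Cc1cc(CCC#N)cc(C)c1Oc1cc(Nc2ccc(C#N)cc2)c(N)cc1C(F)(F)F` gives > 5
- compound 3 `COC(=O)c1cc(N)c(Nc2ccc(C#N)cc2)cc1Oc1c(C)cc(CCC#N)cc1C` gives 4.15

The entry for compound 2 is a limit of the assay and not a number. Its position is therefore known only as the limit of > 5 in this assay, at which 1 of the 3 values shown sits.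

Compound 4 `Cc1cc(C#N)cc(C)c1Oc1cc(Nc2ccc(C#N)cc2)c(N)cc1C(F)(F)F` differs from compound 2 at one place (cyano in place of 2-cyanoethyl on an aromatic carbon). That place is meta to two methyl groups and para to a large group.

Going by the values given here, no measured step touches the 2-cyanoethyl group, so the three steps give only a sense of scale for this assay. They are a number at least 1.32 log units higher from compound 1 to compound 2 (beyond the scatter) and a number 0.47 log units higher from compound 1 to compound 3 (beyond the scatter) and a number at least 0.85 log units lower from compound 2 to compound 3 (beyond the scatter). Both the leaving and the entering group end in a nitrile. A small fall is therefore expected, no larger than the modest change seen in the step to compound 3 a number 0.47 log units higher from compound 1 to compound 3 (beyond the scatter), since the entering group has fewer heavy atoms.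

The expected change is a number at least 0.10 log units lower from compound 2 to compound 4 (that floor lies within the scatter), an estimate that starts from a limit. For compound 4 the estimated value is 4.9, with an expected range from 4.3 to 5.5.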

Compound 4, partition coefficient: > 5
Compound 4: only a limit was reported; the forecaster's own chance of this, stated with the estimate: 40%; middle value at least 0.10 log units away from the limit.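

In this assay compound 4 gives > 5, a limit of the assay and not a number. Compound 2 gives > 5, also a limit. No step can be read between compound 2 and compound 4: the limit of > 5 in this assay, at which 2 of the 4 values shown sit.

The compounds shown leave open whether cyano in place of 2-cyanoethyl shifts the value at all, and in which direction.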